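Shortening the aryl ether chain in a cyclic sulfonate series

A few compounds are considered here, and "the series" means these few. Any claim that something is new, unique, unknown or untested is made for them only; others in the source may bear on it.

The three measured compounds share one core and differ only in the group on the ether oxygen. Compound 1 `CCC1(Cc2ccccc2)OS(=O)(=O)C=C1OCc1ccc(Cl)cc1` carries a 4-chlorobenzyl group. In an ADME assay on HEL cells (Homo sapiens) for cytotoxicity, with a stated time of 3 days (a higher number here means that more compound is tolerated, a lower number that less compound is tolerated), compound 1 reaches only the assay limit, > 200000 nM, which is a limit and not a number. Compound 2 `CCC1(Cc2ccccc2)OS(=O)(=O)C=C1OCc1ccc(Cl)c(Cl)c1`, with a 3,4-dichlorobenzyl group, gives 36700 nM, the step of an at least 5.4-fold lower number from compound 1 to compound 2 (0.73 log units; beyond the scatter). Compound 3 `CCC1(Cc2ccccc2)OS(=O)(=O)C=C1OCCCc1ccccc1`, with a phenethyl group in place of the chlorinated benzyl groups, gives 133000 nM, the highest of the two numbers, the nearest being a 3.6-fold higher number from compound 2 to compound 3 (0.56 log units; beyond the scatter); against compound 1 the step is an at least 1.5-fold lower number from compound 1 to compound 3 (0.17 log units; that floor lies within the scatter).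

Compound 4 `CCC1(Cc2ccccc2)OS(=O)(=O)C=C1OCCc1ccccc1` is the next compound. The difference from compound 3 is phenyl in place of benzyl on a saturated chain carbon, two bonds along the chain from an oxygen on an unsaturated carbon. The two steps that bear on it both lead into compound 3 from benzyl-type groups, and neither the modest step from compound 2 nor the step from compound 1 that stays within the scatter points to a large change in this assay for the unsubstituted benzyl. Compound 4 is therefore expected to sit close to compound 3, the step being about a 1.1-fold higher number from compound 3 to compound 4 (0.05 log units; within the scatter). For compound 4 the estimate is 150000 nM, with a range from 60000 nM to 300000 nM.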

Compound 4, half-maximal cytotoxic concentration: 48000 nM
Compound 4: middle estimate off by 3.1-fold (0.49 log units), on the high side, and the stated range ends above it.
By their numbers in this assay, from the lowest: compounds 2 and 4 (each within the scatter of the next); then compound 3. At a limit, above all of these: compound 1.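

Removing one carbon from the chain, with phenyl in place of benzyl on a saturated chain carbon, two bonds along the chain from an oxygen on an unsaturated carbon, does change the reading in this assay: the result is a 2.8-fold lower number from compound 3 to compound 4 (0.44 log units; beyond the scatter), so chain length alone moves the number here, with no chlorine involved in the change. Chlorine is also not needed to reach the lower level seen so far, since the unchlorinated chain and the 3,4-dichlorobenzyl group cannot be told apart, at a 1.3-fold higher number from compound 2 to compound 4 (0.12 log units; within the scatter). Against the 4-chlorobenzyl group the result reads an at least 4.1-fold lower number from compound 1 to compound 4 (0.61 log units; beyond the scatter), and that size is only a floor, because the starting value is a limit and not a number: the limit of > 200000 nM in this assay, at which 1 of the 4 values shown sits.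

With only these chain lengths in hand, the compounds shown cannot tell whether a longer chain would continue the rise seen with compound 3 or reverse it. They also leave open whether chlorine on the ring of compound 4 would change its reading, and whether an amine or a carboxylic acid in place of the terminal phenyl would be tolerated differently.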